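From benzyl to 3-isopropylphenyl on the shared core

The source may report more compounds than this note shows. Statements on the series, on what has been measured and on what is new or still open speak of the compounds shown alone.

Compound 3 `CN1CCN(c2ccc(Nc3ncc(Cl)c(NCc4ccccc4)n3)nc2)CC1` is one of three compounds examined in a functional assay on MDA-MB-231 cells (Homo sapiens) for inhibition, read by CCK-8 assay, with a stated time of 48 h; a higher number here means a weaker inhibitor of growth, a lower number a stronger inhibitor of growth. In this assay compound 3 gives 24800 nM, the highest of the two numbers reported; compound 2 `CCN1CCN(c2ccc(Nc3ncc(Cl)c(Nc4ccccc4C)n3)cc2)CC1` gives 3040 nM, a lower number beyond the scatter. Compound 1 `Cc1ccccc1Nc1nc(NC2CC2)ncc1Cl` gives only a limit of the assay, > 100000 nM, and so no number for it is known (the limit of > 100000 nM in this assay, at which 1 of the 3 values shown sits).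

Compound 4 `CC(C)c1cccc(Nc2nc(Nc3ccc(N4CCN(C)CC4)cn3)ncc2Cl)c1` has not yet been measured. It differs from compound 3 in one place: 3-isopropylphenyl in place of benzyl on a nitrogen on an aromatic ring. Among the measured compounds shown here, no step between measured compounds of the same kind is available, so the size of this step can only be expected. Compound 4 is expected to be a stronger inhibitor of growth than compound 3, with a step of a 5.0-fold lower number from compound 3 to compound 4 (0.70 log units; beyond the scatter), because compound 2, which also carries an aromatic carbon ring directly on that nitrogen, gives 3040 nM. Compound 4 is therefore estimated at 5000 nM, within a range from 1500 nM to 20000 nM in this assay.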

Compound 4, concentration for 50% growth inhibition: 5590 nM
For compound 4 the middle estimate is 1.1-fold (0.05 log units) below the measured one; measured number inside the range.
By their numbers in this assay, from the lowest: compounds 2 and 4 (each within the scatter of the next); then compound 3. At a limit, above all of these: compound 1.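

In this assay the change on this nitrogen gives the first step measured in one place on the shared core, and 3-isopropylphenyl in place of benzyl comes with a 4.4-fold lower number from compound 3 to compound 4 (0.65 log units; beyond the scatter) and a modest gain. This shows that the position responds to what is attached there, and that benzylamino is not required, since (3-isopropylphenyl)amino is tolerated and gives the stronger inhibitor of growth of the pair. No measurement shown bears on the cause of this step.

The single step joins two changes, the loss of the benzyl form and the arrival of isopropyl, and the compounds shown cannot separate them. From the compounds shown here alone, a plain phenyl on this nitrogen would divide the step, and it remains open how an amine or a carboxylic acid on that ring would read.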